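A Second Methoxy Group on a Weaker Core

A few compounds are considered here, and "the series" means these few. Any claim that something is new, unique, unknown or untested is made for them only; others in the source may bear on it.

Compound 1 `C=CCCCCOc1ccccc1-c1cnc(OCCC=C)n1C` gives 29000 nM in a functional assay on T98G cells (Homo sapiens) for inhibition, read by colorimetric assay and MTT assay, with a stated time of 72 h; on this read-out lower numbers stand for stronger inhibition and higher numbers for weaker inhibition.
Compound 2 `C=CCCCCOc1ccc(OC)cc1-c1cnc(OCCC=C)n1C` gives 74000 nM in this assay.
Compound 3 `C=CCCCCOc1ncc(-c2ccccc2OC)n1C` gives 5000 nM in this assay.

Compound 3 has the lowest number of the three measured compounds; compound 1 and compound 2 sit at higher numbers, both beyond the scatter. Compound 1 and compound 3 are built on different cores, and the difference between the two cores is not broken down here.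

Compound 2 differs from compound 1 by methoxy in place of hydrogen on an aromatic carbon, and that change gave a 2.6-fold higher number from compound 1 to compound 2 (0.41 log units; beyond the scatter). Compound 4 `C=CCCCCOc1ncc(-c2cccc(OC)c2OC)n1C` differs from compound 3 by methoxy in place of hydrogen on an aromatic carbon. This is the same kind of change, not the same: in compound 2 the new group is meta to a large group and para to a (hex-5-en-1-yl)oxy group, while in compound 4 it is ortho to a methoxy group and meta to a large group. Resting on the step seen from compound 1 to compound 2, compound 4 is expected to shift by about a 2.4-fold higher number from compound 3 to compound 4 (0.38 log units; beyond the scatter) in this assay, a modest rise in the number. Compound 4 is therefore estimated at 12000 nM, likely between 4000 nM and 36000 nM.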

Compound 4, half-maximal inhibitory concentration: 35000 nM
For compound 4 the middle estimate is 2.9-fold (0.46 log units) below the measured one; low and high end bracket the measured number.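

Placing a methoxy group on an aromatic carbon gave a 7.0-fold higher number from compound 3 to compound 4 (0.85 log units; beyond the scatter) in this assay, which means weaker inhibition, the same direction as on the core of compound 1. The direction carried over from one core to the other, but the size of the step did not: the same change on two cores in this assay, a 2.6-fold higher number (0.41 log units; beyond the scatter) from compound 1 to compound 2 and a 7.0-fold higher number (0.85 log units; beyond the scatter) from compound 3 to compound 4, 2.7-fold (0.44 log units) apart, beyond the scatter of two such steps This does not show that the core alone sets the size of the step: in compound 4 the new methoxy group is ortho to a methoxy group, a place it does not hold in compound 2, so core and position change together, and two pairs cannot give a general rule.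

The compounds shown leave open whether a smaller group on that same aromatic carbon, such as a fluorine atom or a hydroxyl group, or an amine there, would also raise the number. They also leave open whether the step would keep its size with a shorter chain in place of the hex-5-en-1-yl chain.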